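The source may hold more compounds than are shown below. What is called first, only, known or untested is meant among the compounds shown, and "the series" means these compounds.

Compound 1, `O=C(N/N=C/C1=Cc2ccccc2OC1)c1cccs1`: 22100 nM in a toxicity assay on HEK-293T cells (Homo sapiens) for cytotoxicity, read by MTT assay, with a stated time of 72 h; a lower number here means a stronger inhibitor, a higher number a weaker inhibitor
Compound 2, `CC1Oc2ccccc2C=C1/C=N/NC(=O)c1cccs1`: "not determined" (no result reported) in this assay
Compound 3, `O=C(N/N=C/C1=Cc2ccccc2OC1c1ccccc1)c1cccs1`: "not determined" (no result reported) in this assay

Compound 3 has no single number in this assay; the same is true of compound 2, so only compound 1 carries a measured value among the three. Compound 3 therefore stands without a position of its own on this read-out, and compound 1 gives the only anchor for the shared core, with 22100 nM in this assay.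

The step to compound 4, `O=C(N/N=C/C1=Cc2ccccc2OC1c1ccccc1)c1ccc(F)cc1`, consists of 4-fluorophenyl in place of thiophen-2-yl on a carbonyl carbon. Among the measured compounds shown here, no measured step connects compound 3 and compound 4, and no measured pair shows what exchanging the group on the carbonyl carbon does to the half-maximal inhibitory concentration in this assay. For the measured compounds named here, with nothing known for compound 3 itself, the only reference point is compound 1, so the expectation rests on its value alone. A move beyond the scatter is not anticipated in either direction; compound 4 is expected to fall in the same weakly cytotoxic region as compound 1.

Compound 4 is therefore estimated at 25000 nM in this assay, with a range from 8000 nM to 80000 nM.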

Compound 4, half-maximal inhibitory concentration: 30900 nM
Compound 4: the middle estimate sits 1.2-fold (0.09 log units) below what was measured; the range from low to high includes it.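

In this assay, among the compounds shown here, compound 3 has no single number, so no step to compound 4 at 30900 nM can be read from these results. The compounds shown leave open what exchanging thiophen-2-yl for 4-fluorophenyl on the carbonyl carbon does to this read-out. Nothing available bears on the value of compound 4.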